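A few compounds are considered here, and "the series" means these few. Any claim that something is new, unique, unknown or untested is made for them only; others in the source may bear on it.

Compound 1 `Cc1cc2nc(NC(=O)c3cc(-c4ccc(F)cc4)n4nc(-c5ccccc5)cc4n3)sc2cc1C`: 12900 nM
Compound 2 `COc1ccc(-c2cc(C(=O)Nc3nc4cc(C)c(C)cc4s3)nc3cc(-c4ccccc4)nn23)cc1`: 12300 nM

Going by the values given here, in a functional assay on DU-145 cells (Homo sapiens) for cytotoxicity, read by MTT assay, with a stated time of 48 h (on this read-out higher numbers stand for weaker inhibition and lower numbers for stronger inhibition), compound 2 has the lowest of the two numbers measured so far, but its nearest neighbour, compound 1, sits a 1.0-fold lower number from compound 1 to compound 2 (0.02 log units; within the scatter), so the two values cannot be told apart on this read-out. Compound 3 `COc1ccc(-c2cc(C(=O)Nc3nc4cc(C)c(C)cc4s3)nc3cc(-c4ccccc4)nn23)cc1OC` differs from compound 2 by methoxy in place of hydrogen on an aromatic carbon. Among the compounds with values here, only one measured step bears on this change: the swap of one substituent for another on an aromatic carbon in going a 1.0-fold lower number from compound 1 to compound 2 (0.02 log units; within the scatter), which left this assay unmoved. On that basis no shift beyond the scatter is expected for compound 3, and the step is estimated as a 1.0-fold lower number from compound 2 to compound 3 (0.01 log units; within the scatter). Within the data shown here, the one comparison available says nothing about whether adding a second methoxy will matter, and the pair of values of compound 1 and compound 2 gives no hint of a direction. Compound 3 is therefore expected to give about 12000 nM in this assay, with a likely range from 5000 nM to 30000 nM.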

Compound 3, half-maximal inhibitory concentration: 6910 nM
Estimate against measurement, compound 3: 1.7-fold (0.24 log units) above; measured number inside the range.
By their numbers in this assay, from the lowest: compounds 3, 2 and 1 (each within the scatter of the next).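

In this assay the earlier pair had only exchanged one substituent for another on a single aromatic carbon, whereas compound 3 keeps the methoxy of compound 2 and places a second methoxy on a further aromatic carbon, ortho to a methoxy group. This addition reads as a 1.8-fold lower number from compound 2 to compound 3 (0.25 log units; within the scatter) and therefore gives no shift that can be separated from repeated measurement. Set against the 4-fluorophenyl of compound 1, the 3,4-dimethoxyphenyl group reads as a 1.9-fold lower number from compound 1 to compound 3 (0.27 log units; within the scatter) and so, with fluoro, methoxy and two methoxy groups on this ring, the three compounds cannot be told apart on this read-out.

The compounds shown leave open whether an amine, a carboxylic acid or a longer alkoxy chain on this ring would move the number beyond the scatter, and whether any change to the other phenyl group or to the two methyl groups of the shared core would do so. No measurement is at hand that could account for these numbers.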